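A few compounds are considered here, and "the series" means these few. Any claim that something is new, unique, unknown or untested is made for them only; others in the source may bear on it.

Measured so far in a functional assay on HepG2 cells (Homo sapiens) for cytotoxicity, read by sulforhodamine B assay, with a stated time of 48 h; on this read-out lower numbers stand for stronger inhibition and higher numbers for weaker inhibition:
compound 1 `COc1ccc(/C=C/C(=O)c2cccc(-c3ccc(F)cc3)c2)cc1OC` gives 5370 nM
compound 2 `COc1ccc(/C=C/C(=O)c2ccc(NC(C)=O)c(-c3ccc(F)cc3)c2)cc1OC` gives 5630 nM

Within the data shown here, on these two numbers compound 1 stands lowest, with compound 2 as its only neighbour, and the gap between them is within the scatter, so the two cannot be told apart. Among the measured compounds shown here, the one measured step, a 1.0-fold higher number from compound 1 to compound 2 (0.02 log units; within the scatter), is a change elsewhere in the molecule, acetamido in place of hydrogen on an aromatic carbon, and it left the number essentially where it was.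

Compound 3 `COc1ccc(/C=C/C(=O)c2cccc(-c3ccc(F)cc3)c2)cc1` has not yet been measured in this assay. It differs from compound 1 by hydrogen in place of methoxy on an aromatic carbon. For the measured compounds named here, no measured step touches this part of the shared core, so the data say nothing direct about how large this change should be. Going by the values given here, the single step available shows only that one modification at a different site stayed within the scatter, which is weak guidance at best. A small step is therefore expected, a 1.1-fold higher number from compound 1 to compound 3 (0.05 log units; within the scatter), with no clear direction. Compound 3 is estimated at 6000 nM, within a range from 2500 nM to 15000 nM, the width reflecting the absence of any directly comparable step.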

Compound 3, half-maximal inhibitory concentration: 5650 nM
Compound 3: the middle estimate sits 1.1-fold (0.03 log units) above what was measured; measured number inside the range.
By their numbers in this assay, from the lowest: compounds 1, 2 and 3 (each within the scatter of the next).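

In this assay, among these compounds, the exchange of methoxy for hydrogen gives the first measured step at this position (a 1.1-fold higher number from compound 1 to compound 3 (0.02 log units; within the scatter)), so compound 1 and compound 3 cannot be told apart. The position is an aromatic carbon ortho to a methoxy group and meta to a large group, and the earlier step, made elsewhere in the molecule, could not speak to it; here, losing the 2 heavy atoms and 1 hydrogen-bond acceptor of the methoxy group leaves the number within the scatter. Nothing at hand explains this result.

As far as these compounds go, only hydrogen and methoxy have been seen at this position, so it remains open whether an amine, a carboxylic acid or a longer alkoxy chain there would also leave the number within the scatter. The neighbouring methoxy group is still present in compound 3, so these compounds also do not show what hydrogen in place of that group, or of both methoxy groups together, would do.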